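This account rests on a few compounds, and the source may have more. Where it says the series, first, only, none or still open, it means among the compounds named here.

Measured in a functional assay on V79-379A cells (Cricetulus griseus) for cytotoxicity, read by MTT assay, in the presence of a further agent that is not named here; on this read-out lower numbers stand for stronger inhibition and higher numbers for weaker inhibition:
- compound 1 `COC1=CC(=O)c2c(c(COC(=O)c3ccc(F)cc3)c(C)n2C)C1=O`: 300 nM
- compound 2 `COC1=CC(=O)c2c(c(COC(=O)c3ccccc3)cn2C)C1=O`: 40 nM
- compound 3 `COC1=CC(=O)c2c(c(COC(=O)c3ccccc3)c(C)n2C)C1=O`: 200 nM

Compound 3, at 200 nM, holds the second highest of the three numbers. The two measured steps that end on it are a 1.5-fold lower number from compound 1 to compound 3 (0.18 log units; within the scatter) and a 5.0-fold higher number from compound 2 to compound 3 (0.70 log units; beyond the scatter).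

The next compound is compound 4 `COC1=CC(=O)c2c(c(COC(C)=O)c(C)n2C)C1=O`, which differs from compound 3 as follows: methyl in place of phenyl on a carbonyl carbon. This is methyl in place of phenyl on a carbonyl carbon, or benzoyl to acetyl.

Going by the values given here, no measured step replaces this group as a whole, so the evidence is indirect. Among the compounds with values here, the only step that touches the benzoyl group is a 1.5-fold lower number from compound 1 to compound 3 (0.18 log units; within the scatter), and it stays within the scatter, but it swaps a single substituent and keeps the ring. The larger step, a 5.0-fold higher number from compound 2 to compound 3 (0.70 log units; beyond the scatter), concerns a methyl on an aromatic carbon of the shared core. That methyl is retained in compound 4, so this step sets no size for the present change.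

The data support no direction, and no shift beyond the scatter can be argued from them. The expected step is no change at the digits printed from compound 3 to compound 4 (within the scatter), with wide uncertainty. For compound 4 the estimated value is 200 nM, with an expected range from 60 nM to 700 nM.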

Compound 4, half-maximal inhibitory concentration: 2500 nM
Compound 4: the middle estimate sits 13-fold (1.10 log units) below what was measured; measured number above the stated range.
By their numbers in this assay, from the lowest: compound 2; then compounds 3 and 1 (each within the scatter of the next); then compound 4.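

In this assay, going by these compounds alone, the group on the carbonyl carbon matters at this position, which the earlier compounds could not show: a 13-fold higher number from compound 3 to compound 4 (1.10 log units; beyond the scatter), and an 8.3-fold higher number from compound 1 to compound 4 (0.92 log units; beyond the scatter), so the acetyl compound parts from both aryl compounds beyond the scatter. Changing a substituent on the aromatic ring gave only a 1.5-fold lower number from compound 1 to compound 3 (0.18 log units; within the scatter), so across these three compounds the large change comes with losing the ring as a whole, not with editing it. Nothing measured here explains the loss on going to methyl.

From the compounds shown here alone, two compounds with methyl on the carbonyl carbon cannot be compared yet, since the step rests on compound 4 alone, and it remains open whether the aromatic ring itself counts or simply the size of the group, which a cyclohexyl group or a longer chain such as pentyl on the same carbonyl carbon would separate. Also open, going by these compounds, is whether benzoyl to acetyl costs as much on the core of compound 2, which lacks the methyl on the aromatic carbon, and whether an amine or a carboxylic acid on the phenyl ring would move the number at all.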